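Swapping Nitro for Sulfamoyl on the Aryl Ring

This account rests on a few compounds, and the source may have more. Where it says the series, first, only, none or still open, it means among the compounds named here.

compound 1 `COc1ccc(-c2ncc(C(=O)O)c(=O)[nH]2)c(OC)c1` — 5 mg/kg
compound 2 `CCOc1ccc([N+](=O)[O-])cc1-c1ncc(C(=O)O)c(=O)[nH]1` — 25 mg/kg

In a functional assay on the whole organism (strain Sprague-Dawley) for inhibition, with Rattus norvegicus as the target, with a stated time of 10 min (on this read-out higher numbers stand for an effect only at larger amounts of compound and lower numbers for an effect already at smaller amounts), compound 1 gives 5 mg/kg, and compound 2 gives 25 mg/kg. Compound 2 thus stands highest of the two numbers; its nearest neighbour is compound 1, whose lower number lies beyond the scatter. Compound 3 `CCOc1ccc(S(=O)(=O)N(C)C(C)C)cc1-c1ncc(C(=O)O)c(=O)[nH]1` has not yet been measured. It differs from compound 2 in one place: isopropyl(methyl)sulfamoyl in place of nitro on an aromatic carbon. Among the measured compounds shown here, no measured pair shows this change, so its effect is open. A small downward step is expected, a 1.7-fold lower number from compound 2 to compound 3 (0.22 log units; within the scatter), not beyond the scatter. Compound 3 is estimated at 15 mg/kg, with a range from 5 mg/kg to 50 mg/kg.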

Compound 3, dose for 50% inhibition: > 10 mg/kg
Compound 3: a limit, no number; the forecaster's own chance of this, stated with the estimate: 10%; the middle value is on the limit's open side.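

In this assay compound 3 gives > 10 mg/kg, which is a limit and not a number. Among the compounds shown here, no step from compound 2 to compound 3 can be read. As far as these compounds go, whether isopropyl(methyl)sulfamoyl in place of nitro raises, lowers or leaves the number unchanged stays open.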